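The source may report more compounds than this note shows. Statements on the series, on what has been measured and on what is new or still open speak of the compounds shown alone.

Compound 1 `O=C(CCCCCOc1cccc(-c2nnc(-c3ccccc3)s2)c1)NO` gives 470 nM
Compound 2 `O=C(CCCCCCOc1cccc(-c2nnc(-c3ccccc3)s2)c1)NO` gives 2900 nM

In a functional assay on HCT-116 cells (Homo sapiens) for antiproliferative activity, read by CCK-8 assay, with a stated time of 48 h (a lower number here means a stronger inhibitor, a higher number a weaker inhibitor), compound 2 stands at 2900 nM as the higher of the two numbers, which makes it the weaker inhibitor of the pair. Compound 3 `O=C(CCCCCCOc1cccc(-c2nnc(-c3ccccc3Cl)s2)c1)NO` keeps everything in compound 2 except one spot: chloro in place of hydrogen on an aromatic carbon turning phenyl to 2-chlorophenyl, on an aromatic carbon ortho to a large group.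

Among the measured compounds shown here, the only measured step is a 6.2-fold higher number from compound 1 to compound 2 (0.79 log units; beyond the scatter) and it lies on the saturated chain, so it says nothing direct about a chloro group. It does show that a single small edit can move the number in this assay beyond the scatter, so the range has to stay wide. For the measured compounds named here, no measured step involves this ring, so the data give no firm direction. The expected change is therefore no larger than the scatter, with only a slight lean towards a lower number: the estimated step is a 1.5-fold lower number from compound 2 to compound 3 (0.16 log units; within the scatter) and no more than that is expected. Compound 3 is estimated at 2000 nM with an expected range from 700 nM to 6000 nM in this measurement.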

Compound 3, half-maximal inhibitory concentration: 10000 nM
Estimate against measurement, compound 3: 5.0-fold (0.70 log units) below, and the stated range ends below it.
By their numbers in this assay, from the lowest: compound 1; then compound 2; then compound 3.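

In this assay, among the compounds shown here, putting chloro in place of hydrogen gives a 3.4-fold higher number from compound 2 to compound 3 (0.54 log units; beyond the scatter), so the phenyl ring, which no earlier pair touched, is also a place where one small edit matters. Here a single chlorine atom on an aromatic carbon, ortho to a large group, moves the number towards weaker inhibition, and this step lies beyond the usual scatter, just as a 6.2-fold higher number from compound 1 to compound 2 (0.79 log units; beyond the scatter) does on the saturated chain. The result therefore shows that the number responds to changes in two separate parts of the molecule, although nothing in the data shown explains why this chlorine has this effect.

The compounds shown leave open whether a different group at this spot, such as fluoro, methyl or methoxy, would raise the number in the same way, or whether chloro on another carbon of this ring would do so. They also leave open whether the same chloro group would produce a step of similar size on the shorter chain of compound 1, where the starting number is lower.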